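A 4-chlorophenyl in place of 2-methylphenyl

This account rests on a few compounds, and the source may have more. Where it says the series, first, only, none or still open, it means among the compounds named here.

In an ADME assay on HUVEC cells (Homo sapiens) for inhibition, read by CCK-8 assay, with a stated time of 24 h, in the presence of a further agent that is not named here (a lower number here means a stronger inhibitor, a higher number a weaker inhibitor), compound 1 `O=C1Nc2ccc(F)cc2C1=Cc1ccc(-c2cn(-c3ccccc3)nn2)cc1` gives 13700 nM, and compound 2 `Cc1ccccc1-n1cc(-c2ccc(C=C3C(=O)Nc4ccc(F)cc43)cc2)nn1` gives 8630 nM. These two values lie within the scatter of each other, so the numbers do not separate compound 2 from compound 1. Within the data shown here, the only measured step is a 1.6-fold lower number from compound 1 to compound 2 (0.20 log units; within the scatter), with methyl in place of hydrogen on an aromatic carbon.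

Compound 3 `O=C1Nc2ccc(F)cc2C1=Cc1ccc(-c2cn(-c3ccc(Cl)cc3)nn2)cc1` keeps the shared core of compound 2 and changes one group: 4-chlorophenyl in place of 2-methylphenyl on an aromatic nitrogen. In words, this puts 4-chlorophenyl in place of 2-methylphenyl on an aromatic nitrogen. Among the measured compounds shown here, no measured compound carries chlorine, so the data offer no direct guide to this group. The closest evidence is the change on this same ring, a 1.6-fold lower number from compound 1 to compound 2 (0.20 log units; within the scatter), which did not move the value beyond the scatter. A step of similar modest size is therefore the working expectation, with no clear direction. The expected step is a 1.0-fold higher number from compound 2 to compound 3 (0.02 log units; within the scatter), which stays within the scatter in this assay. For compound 3 the estimated value is 9000 nM, with an expected range from 3500 nM to 20000 nM.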

Compound 3, half-maximal inhibitory concentration: 19600 nM
The estimate for compound 3 lay 2.2-fold (0.34 log units) below the measured number; the range from low to high includes it.
By their numbers in this assay, from the lowest: compounds 2, 1 and 3 (each within the scatter of the next, the first and the last beyond it).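

Among these compounds, on the ring held by the aromatic nitrogen, this result gives the first step beyond the scatter in this assay: 4-chlorophenyl in place of 2-methylphenyl gives a 2.3-fold higher number from compound 2 to compound 3 (0.36 log units; beyond the scatter), a modest change. Compound 1, with its plain phenyl, offers a second reading of the same result, since adding chloro to this ring gives a 1.4-fold higher number from compound 1 to compound 3 (0.16 log units; within the scatter), so that step alone does not separate compound 3 from compound 1; the two substituted compounds can be told apart from each other, but neither can be told apart from the unsubstituted one. No measurement shown offers an explanation for the step between compound 2 and compound 3.

Methyl and chloro are the only groups shown on this ring, each in a single place, so these compounds cannot tell whether the name of the group or its place on the ring matters more. As far as these compounds go, how a group of a different kind on the same ring, such as an amine or a carboxylic acid, would read in this assay also remains open.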